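The source may hold more compounds than are shown below. What is called first, only, known or untested is meant among the compounds shown, and "the series" means these compounds.

Of the compounds shown here, three from one series have been tested in a functional assay on Huh-7 cells (Homo sapiens) for inhibition, read by sulforhodamine B assay, with a stated time of 72 h; on this read-out higher numbers stand for weaker inhibition and lower numbers for stronger inhibition. Compound 1 `CC(c1ccc(-c2ccccc2)c(F)c1)c1nnc2n1N=C(c1ccc(Cl)cc1Cl)CS2` gives 3700 nM in this assay. Compound 3 `CC(c1ccc(-c2ccccc2)c(F)c1)c1nnc2n1N=C(c1ccc(Br)cc1)CS2` is built from compound 1 by one change, (4-bromophenyl in place of 2,4-dichlorophenyl on a carbon with a double bond to nitrogen), and in this assay compound 3 gives 5000 nM. That change produced a 1.4-fold higher number from compound 1 to compound 3 (0.13 log units; within the scatter), so the two values cannot be told apart with confidence.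

Compound 2 `CC(C)Cc1ccc(C(C)c2nnc3n2N=C(c2ccc(Cl)cc2Cl)CS3)cc1` carries a different core; how the two cores differ is not broken down here. In this assay compound 2 gives 7500 nM, a higher number than compound 1 gives, while its value and that of compound 3 lie within the usual scatter of each other.

Compound 4 `CC(C)Cc1ccc(C(C)c2nnc3n2N=C(c2ccc(Br)cc2)CS3)cc1` has not been measured. It is made from compound 2 by the same change that turns compound 1 into compound 3, namely (4-bromophenyl in place of 2,4-dichlorophenyl on a carbon with a double bond to nitrogen), at a place described in identical words in both pairs. Because a 1.4-fold higher number from compound 1 to compound 3 (0.13 log units; within the scatter) was small, the same change on compound 2 is expected to produce a step of similar size, estimated as a 1.3-fold higher number from compound 2 to compound 4 (0.12 log units; within the scatter). Among the measured compounds shown here, the estimate for compound 4 in this assay is therefore 10000 nM, with a likely range from 4000 nM to 25000 nM, resting on the value of compound 2 and the single earlier example of this change.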

Compound 4, half-maximal inhibitory concentration: 4900 nM
Compound 4: the middle estimate sits 2.0-fold (0.31 log units) above what was measured, within the range that was stated.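

Putting 4-bromophenyl in place of 2,4-dichlorophenyl on the second core gave a 1.5-fold lower number from compound 2 to compound 4 (0.18 log units; within the scatter) in this assay, so this pair of values cannot be told apart with confidence. Set beside the earlier example, the change cannot be said to behave differently on the two cores: the same change on two cores in this assay, a 1.4-fold higher number (0.13 log units; within the scatter) from compound 1 to compound 3 and a 1.5-fold lower number (0.18 log units; within the scatter) from compound 2 to compound 4, 2.1-fold (0.32 log units) apart, within the scatter of two such steps. Across these two pairs, then, the swap carries from one core to the other as a change with no clear effect on this read-out, but this does not show that the two groups are interchangeable in general, and with both steps inside the scatter neither a direction nor a size can be given to the change.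

What the compounds shown leave open is whether the same holds for a group of a different kind on this carbon, such as a phenyl ring carrying an amine or a carboxylic acid, since only 2,4-dichlorophenyl and 4-bromophenyl appear there. From the compounds shown here alone, it is also open whether a third core would respond in the same way, as this comparison rests on just two pairs, both read in this assay.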